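A few compounds are considered here, and "the series" means these few. Any claim that something is new, unique, unknown or untested is made for them only; others in the source may bear on it.

Working notes on the series. In a functional assay on BXPC-3 cells (Homo sapiens) for inhibition, read by MTT assay, with a stated time of 7 days (a higher number here means a weaker inhibitor, a lower number a stronger inhibitor), compound 2 `CCOC(=O)[C@@H]1CCCN(S(=O)(=O)c2ccc(S(=O)(=O)N3CCOCC3)cc2)C1` gives 23400 nM; compound 1 `CCOC(=O)C1CCN(S(=O)(=O)c2ccc(S(=O)(=O)N(CC)CC)cc2)CC1` gives 23100 nM, and the two numbers lie within the scatter of each other. For compound 3 `CCOC(=O)[C@@H]1CCCN(C(=O)c2ccc(S(=O)(=O)N(CC)CC)cc2)C1` the result in this assay is a limit of the assay, > 10000 nM. Compound 4 `CCOC(=O)[C@@H]1CCCN(S(=O)(=O)c2ccc(C(=O)N(CC)CC)cc2)C1` differs from compound 2 by diethylcarbamoyl in place of (morpholin-4-yl)sulfonyl on an aromatic carbon. Within the data shown here, no measured pair shows a step of this kind, so no direction is supported, and the change from compound 2 to compound 4 is expected to stay within the scatter. The estimate for compound 4 in this assay is 24000 nM, in a range of 8000 nM to 80000 nM. This estimate means an expected 1.0-fold higher number from compound 2 to compound 4 (0.01 log units; within the scatter).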

Compound 4, half-maximal inhibitory concentration: 640 nM
Estimate against measurement, compound 4: 38-fold (1.57 log units) above, outside the stated range (below it).
By their numbers in this assay, from the lowest: compound 4; then compounds 1 and 2 (each within the scatter of the next).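

This position is not indifferent in this assay: diethylcarbamoyl in place of (morpholin-4-yl)sulfonyl on an aromatic carbon, para to a large group, gives a 37-fold lower number from compound 2 to compound 4 (1.56 log units; beyond the scatter). The numbers measured earlier lay within the scatter of each other, and this step shows that a single change can move the number far beyond it. The data shown give no cause for this step.

From the compounds shown here alone, the carbonyl and the diethylamino part change together here, and which of them carries the step stays open. Also open, going by these compounds, is whether morpholine-4-carbonyl or a longer dialkyl amide keeps the lower number.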